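A few compounds are considered here, and "the series" means these few. Any claim that something is new, unique, unknown or untested is made for them only; others in the source may bear on it.

Compound 1 `O=C(NC1CCCCC1)c1cc2ccccc2oc1=O` gives 500 nM in an in vitro assay on BTI-TN-5B1-4 cells for inhibition of Amine oxidase [flavin-containing] B (Homo sapiens), read by fluorescence; on this read-out lower numbers stand for stronger inhibition and higher numbers for weaker inhibition. Compound 2 `O=C(Nc1c(F)c(F)c(F)c(F)c1F)c1cc2ccccc2oc1=O` gives 460 nM. Compound 3 `O=C(NC1CCCCC1)c1cc2ccc(OCc3ccccc3)cc2oc1=O` gives 64500 nM.

Among the measured compounds shown here, compound 3 has the highest number of the three, far from compound 1 and compound 2, and the one step measured for it, a 130-fold higher number from compound 1 to compound 3 (2.11 log units; beyond the scatter), is large. Compound 4 `COc1cc(NC(=O)c2cc3ccc(OCc4ccccc4)cc3oc2=O)cc(OC)c1` differs from compound 3 in one place: 3,5-dimethoxyphenyl in place of cyclohexyl on an amide-type nitrogen. For the measured compounds named here, no measured step matches this change. The nearest comparison is compound 1 against compound 2, whose values show that swapping the cyclohexyl for a pentafluorophenyl on the amide nitrogen leaves the number close to where it was, within the usual scatter. On that basis compound 4 is expected to stay near compound 3, with a 1.3-fold lower number from compound 3 to compound 4 (0.11 log units; within the scatter) expected to fall within the scatter. The estimate for compound 4 in this assay is therefore 50000 nM, with a range from 15000 nM to 200000 nM.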

Compound 4, half-maximal inhibitory concentration: 3360 nM
The estimate for compound 4 lay 15-fold (1.17 log units) above the measured number; measured number below the stated range.
By their numbers in this assay, from the lowest: compounds 2 and 1 (each within the scatter of the next); then compound 4; then compound 3.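

With the benzyloxy group on the core, the group on the amide-type nitrogen turns out to matter: 3,5-dimethoxyphenyl in place of cyclohexyl gives a 19-fold lower number from compound 3 to compound 4 (1.28 log units; beyond the scatter) in this assay. The earlier pair without the benzyloxy group gave no such sign, since compound 1 gives 500 nM and compound 2, with pentafluorophenyl at this place, gives 460 nM, values within the scatter of each other. Nothing available explains the step, so the data record its size and not its cause.

The compounds shown do not separate the aromatic ring from its two methoxy groups, which a plain phenyl or a single methoxy on the ring would address. They also leave open whether 3,5-dimethoxyphenyl gives a step of similar size on the core of compound 1, and how an amine on that ring would read.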